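Butyl to methoxy on the ketone-linked ring

The source may report more compounds than this note shows. Statements on the series, on what has been measured and on what is new or still open speak of the compounds shown alone.

Measured in an assay on mitochondria (strain BALB/c) for inhibition of glycerol-3-phosphate acyltransferase 1, mitochondrial (Mus musculus), read by scintillation counting, with a stated time of 10 min; a higher number here means a weaker inhibitor, a lower number a stronger inhibitor:
compound 1 `CCCCCCCCS(=O)(=O)Nc1ccc(-c2cccc(F)c2)cc1C(=O)O` gives 37600 nM;
compound 2 `CCCCCCCCS(=O)(=O)Nc1ccc(-c2ccc(O)cc2)cc1C(=O)O` gives 47300 nM;
compound 3 `CCCCCCCCS(=O)(=O)Nc1ccc(C(=O)c2ccc(CCCC)cc2)cc1C(=O)O` gives 31700 nM.

Compound 3 stands at the lowest of the three numbers, though its gaps to compound 1 and compound 2 both lie within the scatter, so the three cannot be told apart. Compound 4 `CCCCCCCCS(=O)(=O)Nc1ccc(C(=O)c2ccc(OC)cc2)cc1C(=O)O` differs from compound 3 by methoxy in place of butyl on an aromatic carbon. Among the measured compounds shown here, the only measured step, a 1.3-fold higher number from compound 1 to compound 2 (0.10 log units; within the scatter), concerns a different part of the structure and is itself within the scatter; no measured step bears directly on the change in hand. The step of a 1.3-fold higher number from compound 3 to compound 4 (0.10 log units; within the scatter) is therefore expected to stay small, with no clear direction. Compound 4 is estimated at 40000 nM, within 15000 nM to 110000 nM.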

Compound 4, half-maximal inhibitory concentration: 44300 nM
Compound 4: middle estimate off by 1.1-fold (0.04 log units), on the low side; measured number inside the range.
By their numbers in this assay, from the lowest: compounds 3, 1, 4 and 2 (each within the scatter of the next).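

In this assay the position on the ketone-linked ring tolerates this exchange without a readable shift: methoxy in place of butyl gives a 1.4-fold higher number from compound 3 to compound 4 (0.15 log units; within the scatter) and so does not separate the two compounds. Replacing the whole 4-hydroxyphenyl or 3-fluorophenyl group with (4-methoxyphenyl)carbonyl gives a 1.1-fold lower number from compound 2 to compound 4 (0.03 log units; within the scatter) and a 1.2-fold higher number from compound 1 to compound 4 (0.07 log units; within the scatter), so compound 4 cannot be told from either. No measured evidence accounts for these values. Going by these compounds, whether an amine or a longer chain at this position would move the number beyond the scatter remains open.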